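A few compounds are considered here, and "the series" means these few. Any claim that something is new, unique, unknown or untested is made for them only; others in the source may bear on it.

In an ADME assay on HEL cells (Homo sapiens) for cytotoxicity, with a stated time of 3 days (a higher number here means that more compound is tolerated, a lower number that less compound is tolerated), compound 3 `Cc1cc(-n2ccc3cccnc32)cn2c(CSCCc3ccccc3)cnc12` gives 20 ug/mL. Compound 1 `Cc1cc(N2CCN(C)CC2)cn2c(CSCCc3ccccc3)cnc12` gives 20 ug/mL, and compound 2 `Cc1cc(-n2ccnc2)cn2c(CSCCc3ccccc3)cnc12` gives 100 ug/mL. Compound 3 thus stands level with compound 1 at the digits printed, the two sharing the lowest number of the three, while compound 2 lies farthest away, as a 5.0-fold lower number from compound 2 to compound 3 (0.70 log units; beyond the scatter) shows.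

Compound 4 `Cc1cc(C#N)cn2c(CSCCc3ccccc3)cnc12` has not yet been measured. It differs from compound 3 at one place: a group of 2 heavy atoms (1 carbon, 1 nitrogen; no ring) in place of a group of 9 heavy atoms (7 carbon, 2 nitrogen; one five-membered aromatic ring with 1 hetero atom, one six-membered aromatic ring with 1 hetero atom), on an aromatic carbon. The measured steps that bear on this are the swaps on that same aromatic carbon. There, a 5.0-fold higher number from compound 1 to compound 2 (0.70 log units; beyond the scatter) went toward more compound tolerated, whereas no change at the digits printed from compound 1 to compound 3 (within the scatter) stayed within the scatter. Cyano is the smallest group tried at this place, and the one small aromatic group, in compound 2, gave the highest value, 100 ug/mL. Compound 4 is therefore expected to show a 2.5-fold higher number from compound 3 to compound 4 (0.40 log units; beyond the scatter), a modest rise, though with real uncertainty. The estimate for compound 4 is 50 ug/mL, with a range from 20 ug/mL to 100 ug/mL.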

Compound 4, minimum cytotoxic concentration: 20 ug/mL
Compound 4: middle estimate off by 2.5-fold (0.40 log units), on the high side; measured number inside the range.
By their numbers in this assay, from the lowest: compounds 1, 3 and 4 (each within the scatter of the next); then compound 2.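

In this assay a small group at this aromatic carbon does not by itself give a higher number: cyano, with only 2 heavy atoms, shows (no change at the digits printed from compound 3 to compound 4 (within the scatter)) against the larger fused group and (no change at the digits printed from compound 1 to compound 4 (within the scatter)) against 4-methylpiperazin-1-yl. Three quite different groups now sit together, and compound 2 stands apart (with a 5.0-fold lower number from compound 2 to compound 4 (0.70 log units; beyond the scatter)), so the small size of 1H-imidazol-1-yl no longer accounts for its higher number on these data. No measurement here explains why this one group differs from the other three. Still open, on these data alone, is whether a pyrazol-1-yl group would match 1H-imidazol-1-yl. Also open, as far as these compounds go, is whether a primary amine or a carboxylic acid on this aromatic carbon would move the number at all.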